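The compounds below may be only part of what the source reports. "The series", "measured", "known", "first", "only" and "open" are said of these compounds alone.

Compound 1 `Cc1ccc2nc(NC(=O)CNC(=O)c3nn(-c4ccccc4)c(=O)c4ccccc34)sc2c1` gives 35 nM in an assay on L cells for inhibition of Protein-serine O-palmitoleoyltransferase porcupine (Mus musculus), read by reporter gene assay, with a stated time of 24 h (on this read-out higher numbers stand for an effect only at larger amounts of compound and lower numbers for an effect already at smaller amounts), the lowest of the two numbers in hand. Compound 2 `Cc1ccc2nc(NC(=O)CNC(=O)c3nn(-c4ccc(F)cc4)c(=O)c4ccccc34)sc2c1` sits at 100 nM, and the step of a 2.9-fold higher number from compound 1 to compound 2 (0.46 log units; beyond the scatter) corresponds to fluoro in place of hydrogen on an aromatic carbon. Compound 3 `COc1ccc2nc(NC(=O)CNC(=O)c3ccc(=O)n(-c4ccccc4)c3)sc2c1` reaches only the limit of this assay at > 25000 nM. Compound 4 `O=C(CNC(=O)c1nn(-c2ccccc2)c(=O)c2ccccc12)Nc1nc2ccccc2s1` differs from compound 1 by hydrogen in place of methyl on an aromatic carbon. Going by the values given here, no measured step touches this position: the step from compound 1 to compound 2 alters the other aryl ring, and compound 3 is built on a different core. Only a modest shift, if any, is therefore expected, estimated as a 1.7-fold higher number from compound 1 to compound 4 (0.23 log units; within the scatter). Compound 4 is expected to give about 60 nM, within 20 nM to 200 nM.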

Compound 4, half-maximal effective concentration: 2600 nM
The estimate for compound 4 lay 43-fold (1.64 log units) below the measured number, and the stated range ends below it.
By their numbers in this assay, from the lowest: compound 1; then compound 2; then compound 4. At a limit, above all of these: compound 3.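

Removing the methyl, from 6-methyl-1,3-benzothiazol-2-yl to 1,3-benzothiazol-2-yl, gives a 74-fold higher number from compound 1 to compound 4 (1.87 log units; beyond the scatter) in this assay, a far larger step than a 2.9-fold higher number from compound 1 to compound 2 (0.46 log units; beyond the scatter) on the other aryl ring. This single carbon on the shared core therefore matters much more to the read-out than the fluoro change does. Nothing measured here accounts for the size of this step. From the compounds shown here alone, whether a chlorine atom, an ethyl group or a trifluoromethyl group on this same aromatic carbon would hold the number near that of compound 1 stays open.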